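The source may hold more compounds than are shown below. What is called first, only, known or untested is meant among the compounds shown, and "the series" means these compounds.

All three compounds measured so far were tested in a functional assay on LOX IMVI cells (Homo sapiens) for inhibition, read by sulforhodamine B assay, with a stated time of 48 h; a higher number here means a weaker inhibitor of growth, a lower number a stronger inhibitor of growth:

compound 1, `Nc1cc(N)c2nc(-c3ccccc3)c(Oc3ccc(Cl)c(Cl)c3)nc2c1`, gives 16200 nM;
compound 2, `Nc1cc(N)c2nc(-c3ccccc3)c(NCc3ccc(Cl)c(Cl)c3)nc2c1`, gives 2140 nM;
compound 3, `COc1ccc(CNc2nc3cc(N)cc(N)c3nc2-c2ccccc2)cc1OC`, gives 3090 nM.

Compound 3 holds the second highest of these three numbers in this assay. Its nearest neighbour is compound 2: the step of a 1.4-fold higher number from compound 2 to compound 3 (0.16 log units; within the scatter) lies within the scatter, so the two cannot be told apart. Compound 1 gives the highest number of the three, and its gap to compound 3 is beyond the scatter.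

Compound 4, `COc1cc(CNc2nc3cc(N)cc(N)c3nc2-c2ccccc2)cc(OC)c1OC`, has not yet been measured. The change from compound 3 is methoxy in place of hydrogen on an aromatic carbon. Within the data shown here, only one measured step concerns the substituents on this outer ring, a 1.4-fold higher number from compound 2 to compound 3 (0.16 log units; within the scatter), and it was within the scatter. Among the measured compounds shown here, no measured step shows what adding a further methoxy does. The expected step of a 1.1-fold higher number from compound 3 to compound 4 (0.05 log units; within the scatter) is therefore none beyond the scatter. Compound 4 is expected to give about 3500 nM in this assay, within a range from 1500 nM to 9000 nM.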

Compound 4, concentration for 50% growth inhibition: 3160 nM
Beside the measured number, compound 4's estimate is 1.1-fold (0.04 log units) above it, within the range that was stated.
By their numbers in this assay, from the lowest: compounds 2, 3 and 4 (each within the scatter of the next); then compound 1.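

In this assay, putting methoxy in place of hydrogen on this aromatic carbon, ortho to a methoxy group, gives a 1.0-fold higher number from compound 3 to compound 4 (0.01 log units; within the scatter), so compound 3 and compound 4 cannot be told apart. Among these compounds, this is the first measured step that adds a group to the outer ring rather than swapping one substituent for another, and it shows that this position can carry a methoxy with no difference this assay can detect. No available evidence bears on this result.

The compounds shown leave open whether an amine, a carboxylic acid or a longer chain such as butoxy at this position would also give a number within the scatter of compound 3. They also leave open whether a hydroxyl group in place of this methoxy would do the same.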